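Dimethylamino for pyrrolidin-1-yl: notes on the series

The source may report more compounds than this note shows. Statements on the series, on what has been measured and on what is new or still open speak of the compounds shown alone.

Measured so far in an ADME assay on L6 cells (Rattus norvegicus) for cytotoxicity, with a stated time of 72 h; a higher number here means a weaker inhibitor, a lower number a stronger inhibitor:
- compound 1 `CC(=O)OC1CC2(N(C)C)CC(c3ccccc3)C1C(c1ccccc1)C2` gives "not determined" (no result reported)
- compound 2 `O=C(CN1CCCCC1)OC1CC2(N3CCCC3)CC(c3ccccc3)C1C(c1ccccc1)C2` gives 14200 nM

Among the compounds with values here, compound 2 carries the only number, so it has no rank, and compound 1 offers no result for comparison. Compound 3 `CN(C)C12CC(OC(=O)CN3CCCCC3)C(C(c3ccccc3)C1)C(c1ccccc1)C2` is still unmeasured in this assay and differs from compound 2 in one place: dimethylamino in place of pyrrolidin-1-yl on a saturated ring carbon. Within the data shown here, no measured step shows what this exchange does, so the expectation rests on compound 2 alone, at 14200 nM (its only anchor). No step beyond the usual scatter is expected, with a slight lean towards weaker inhibition. The estimated change is a 1.4-fold higher number from compound 2 to compound 3 (0.15 log units; within the scatter) (an expectation only). For compound 3 the estimated value is 20000 nM (expected range 8000 nM to 50000 nM).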

Compound 3, half-maximal inhibitory concentration: 29300 nM
Beside the measured number, compound 3's estimate is 1.5-fold (0.17 log units) below it; measured number inside the range.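

In this assay, within the data shown here, placing dimethylamino where pyrrolidin-1-yl stood on the saturated ring carbon gives a 2.1-fold higher number from compound 2 to compound 3 (0.31 log units; beyond the scatter) and supplies the first measured reading of this exchange. The direction is towards weaker inhibition, so with the ((piperidin-1-yl)methyl)carbonyl)oxy group held constant, this position responds modestly when a ring-bearing group of 5 heavy atoms gives way to an open group of 3 heavy atoms. No measured property accompanies this step, so the data offer no account of its origin.

A single pair cannot show whether the shift belongs to ring loss or to the smaller group. Morpholin-4-yl or a primary amine on the same carbon would show whether the trend extends beyond these two groups.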